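This account rests on a few compounds, and the source may have more. Where it says the series, first, only, none or still open, it means among the compounds named here.

Measured so far in a functional assay on MCF7 cells (Homo sapiens) for antiproliferative activity, read by sulforhodamine B assay, with a stated time of 48 h; a higher number here means a weaker inhibitor, a lower number a stronger inhibitor:
compound 1, `COc1cccc(NS(=O)(=O)c2ccc(N3CCNC3=O)cc2)c1`, gives 120 nM
compound 2, `Cc1cccc(NS(=O)(=O)c2ccc(N3CCNC3=O)cc2)c1`, gives 190 nM
compound 3, `O=C1NCCN1c1ccc(S(=O)(=O)Nc2ccccc2)cc1`, gives 470 nM

Compound 3 gives the highest number of the three. The nearest to it is compound 2, a 2.5-fold higher number from compound 2 to compound 3 (0.39 log units; beyond the scatter); the furthest is compound 1, a 3.9-fold higher number from compound 1 to compound 3 (0.59 log units; beyond the scatter). Between compound 1 and compound 2 the step is a 1.6-fold higher number from compound 1 to compound 2 (0.20 log units; within the scatter), so those two sit within the scatter of each other and neither can be ranked against the other.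

Compound 4 is `Cc1ccc(NS(=O)(=O)c2ccc(N3CCNC3=O)cc2)cc1`. It differs from compound 3 by methyl in place of hydrogen on an aromatic carbon. Going by the values given here, the one measured step that bears on this change is the one from compound 2 to compound 3, a 2.5-fold higher number from compound 2 to compound 3 (0.39 log units; beyond the scatter), read in reverse: taking methyl off the ring raised the number beyond the scatter, and putting it back should lower it. Among the compounds with values here, compound 2 carries its methyl on another aromatic carbon of the same ring, so the transfer to compound 4 is not exact; no measured pair differs by methyl at the place where compound 4 carries it, para to a large group. For compound 4 a modest step down in this assay is therefore expected, a 1.9-fold lower number from compound 3 to compound 4 (0.27 log units; within the scatter). Compound 4 is estimated at 250 nM, with a range of 120 nM to 550 nM.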

Compound 4, half-maximal inhibitory concentration: 610 nM
Beside the measured number, compound 4's estimate is 2.4-fold (0.39 log units) below it, outside the stated range (above it).
By their numbers in this assay, from the lowest: compounds 1 and 2 (each within the scatter of the next); then compounds 3 and 4 (each within the scatter of the next).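

In this assay, adding methyl at the place para to a large group gives no separable change on the unsubstituted phenyl (a 1.3-fold higher number from compound 3 to compound 4 (0.11 log units; within the scatter)), so phenyl to 4-methylphenyl leaves compound 4 unresolved from compound 3. The gain seen with the methyl of compound 2 therefore does not extend to every aromatic carbon of this ring: the two methyl isomers are clearly apart (a 3.2-fold higher number from compound 2 to compound 4 (0.51 log units; beyond the scatter)), and the gap to the 3-methoxyphenyl of compound 1 is larger still (a 5.1-fold higher number from compound 1 to compound 4 (0.71 log units; beyond the scatter)). Among these compounds, the ring position of the added group counts for as much as the presence of the group, and nothing available accounts for the difference between the two methyl positions.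

As far as these compounds go, whether methoxy at the place para to a large group would track the methyl of compound 4 or move the number beyond the scatter from compound 3 remains open. Also open, from the compounds shown here alone, is how an amine or a carboxylic acid would behave on either aromatic carbon, and whether a longer chain such as ethyl or propyl would separate the two positions further.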